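Chloro to methylsulfonyl on a nucleotide agonist series

The compounds below may be only part of what the source reports. "The series", "measured", "known", "first", "only" and "open" are said of these compounds alone.

Measured so far:
Compound 1, `Cc1cccc2c(=O)n([C@@H]3O[C@H](COP(=O)(O)OP(=O)(O)OP(=O)(O)O)[C@@H](O)[C@H]3O)ccc12`, 557 nM
Compound 2, `Cc1ccc2ccn([C@@H]3O[C@H](COP(=O)(O)OP(=O)(O)OP(=O)(O)O)[C@@H](O)[C@H]3O)c(=O)c2c1`, 148 nM
Compound 3, `O=c1c2cc(Cl)ccc2ccn1[C@@H]1O[C@H](COP(=O)(O)OP(=O)(O)OP(=O)(O)O)[C@@H](O)[C@H]1O`, 10 nM

In a functional assay for agonist activity at P2Y purinoceptor 2 (Homo sapiens), read by FLIPR (on this read-out higher numbers stand for an effect only at larger amounts of compound and lower numbers for an effect already at smaller amounts), compound 3 gives the lowest number of the three. Its nearest neighbour is compound 2, which differs from it only by a methyl in place of the chloro, and the step is a 15-fold lower number from compound 2 to compound 3 (1.17 log units; beyond the scatter); compound 1, which carries its methyl elsewhere on the shared core, stands furthest away.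

The unmeasured compound 4, `CS(=O)(=O)c1ccc2ccn([C@@H]3O[C@H](COP(=O)(O)OP(=O)(O)OP(=O)(O)O)[C@@H](O)[C@H]3O)c(=O)c2c1`, differs from compound 3 by a single change: methylsulfonyl in place of chloro on an aromatic carbon. Going by the values given here, no measured step involves a methylsulfonyl, so the only step that bears on this one is a 15-fold lower number from compound 2 to compound 3 (1.17 log units; beyond the scatter), which shows that swapping the group at this position of the core can shift the read-out by a large amount. Among the compounds with values here, with no precedent for the incoming group, the direction must be judged cautiously; since compound 3 already sits at the low end of the range seen, a move back toward the values of compound 1 and compound 2 is judged more likely than a further drop.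

Compound 4 is therefore expected to give 60 nM in this assay, within a range of 10 nM to 400 nM. That estimate corresponds to an expected step of a 6.0-fold higher number from compound 3 to compound 4 (0.78 log units; beyond the scatter), beyond the scatter, in the direction of a higher number.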

Compound 4, half-maximal effective concentration: 650 nM
Beside the measured number, compound 4's estimate is 11-fold (1.03 log units) below it; measured number above the stated range.
By their numbers in this assay, from the lowest: compound 3; then compound 2; then compounds 1 and 4 (each within the scatter of the next).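

In this assay the swap of chloro for methylsulfonyl gives a 65-fold higher number from compound 3 to compound 4 (1.81 log units; beyond the scatter) and so reverses much of the gain seen earlier with a 15-fold lower number from compound 2 to compound 3 (1.17 log units; beyond the scatter) on the same aromatic carbon. The earlier compounds shown here showed only that this position responds to a change of group and that chloro gives a far lower number than methyl; they could not show how much of that low number is lost with a different group. Methylsulfonyl also compares unfavourably with methyl, with a 4.4-fold higher number from compound 2 to compound 4 (0.64 log units; beyond the scatter) as the step, so the three groups at this place run from chloro with the lowest number, through methyl, to methylsulfonyl with the highest, and each step lies beyond the scatter.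

On these data alone, it remains open where other groups at this aromatic carbon, such as bromo, a nitrile, an amine or a carboxylic acid, would fall on that scale, and whether any would go lower than chloro. Methylsulfonyl brings more heavy atoms and two hydrogen-bond acceptors that chloro lacks, but no measurement here tells which of these differences, if either, accounts for the higher number.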